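Enantiomer step on the shared core in the agonist assay

The source may report more compounds than this note shows. Statements on the series, on what has been measured and on what is new or still open speak of the compounds shown alone.

Measured compounds:
- Compound 1, `CCN(C[C@@H]1COC(N)=N1)c1ccccc1`: in a functional assay on HEK293 cells for agonist activity at trace amine-associated receptor 1 (Homo sapiens), read by cAMP accumulation, with a stated time of 30 min (on this read-out lower numbers stand for smaller maximal responses and higher numbers for larger maximal responses), compound 1 gives 94%
- Compound 2, `NC1=N[C@@H](c2ccccc2Cl)CO1`: in this assay compound 2 gives 100%
- Compound 3, `Cc1cc(Cl)ccc1[C@H]1COC(N)=N1`: in this assay compound 3 gives 78%

Compound 1 holds the second highest of the three numbers in this assay. Its nearest neighbour is compound 2, a number that sits only slightly higher and within the scatter, so no order between the two can be read. Compound 3 lies furthest away, its number being lower than that of compound 1 by more than the scatter.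

Compound 4, `CCN(C[C@H]1COC(N)=N1)c1ccccc1`, is still to be measured in this assay. Relative to compound 1 the change is the two compounds have the same atoms and bonds and differ only in configuration as drawn: 1 of 1 stereo elements differ; a stereocentre at a saturated ring carbon is drawn R in compound 1 and S in compound 4. Among the compounds with values here, no pair of measured compounds here differs in one place, so there is no measured step on which to rest a size. With a change of configuration alone, a small downward step is expected, one that may well stay within the scatter. For compound 4 the expected value in this assay is 85%, with a range from 55% to 105%, which corresponds to an expected step of a number 9 percentage points lower from compound 1 to compound 4 (within the scatter).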

Compound 4, largest response reached (Emax), in percent of the reference or control that the assay uses: 87%
The estimate for compound 4 lay 2 percentage points below the measured number; the measured number falls inside the stated range.
By their numbers in this assay, from the lowest: compounds 3, 4, 1 and 2 (each within the scatter of the next, the first and the last beyond it).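

In this assay, the series now has its first step at a single place, the stereocentre at a saturated ring carbon: a number 7 percentage points lower from compound 1 to compound 4 (within the scatter). This step can be tied to that one place alone: the fact that compounds 1 and 4 differ only in the configuration as drawn. With the R and S forms within the scatter of each other, this read-out shows no clear dependence of the largest response on configuration at this position, for this pair only.

From the compounds shown here alone, whether the same holds with a propyl chain in place of the ethyl group stays open, as does the outcome of the same change of configuration on compound 2 or compound 3. Also open, going by these compounds, is whether configuration at this position affects the concentration needed to reach the largest response, which this read-out does not show.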